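One Flipped Stereocentre, One Number to Go On

The compounds below may be only part of what the source reports. "The series", "measured", "known", "first", "only" and "open" are said of these compounds alone.

Among the compounds with values here, only one compound in this small set has a measured value so far. In a functional assay on SF-295 cells (Homo sapiens) for inhibition, read by sulforhodamine B assay, with a stated time of 48 h (a higher number here means a weaker inhibitor of growth, a lower number a stronger inhibitor of growth), compound 2 `COc1ccc(C2([C@H]3C[C@H](n4cc(C)c(=O)[nH]c4=O)O[C@@H]3CO[Si](C)(C)C(C)(C)C)SCCCS2)cc1OC` gives 3720 nM. For compound 1 `Cc1cn([C@H]2C[C@H](CC3=CC(=O)C(=O)C=C3)[C@@H](CO[Si](C)(C)C(C)(C)C)O2)c(=O)[nH]c1=O` the entry in this assay reads no result reported and so compound 2 cannot yet be ranked against anything else.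

Compound 3 `COc1ccc(C2([C@H]3C[C@@H](n4cc(C)c(=O)[nH]c4=O)O[C@@H]3CO[Si](C)(C)C(C)(C)C)SCCCS2)cc1OC` is built from the same atoms, joined in the same order, as compound 2. The two differ only in how one part is arranged in space (the two compounds have the same atoms and bonds and differ only in configuration as drawn: 1 of 3 stereo elements differ; a stereocentre at a saturated ring carbon is drawn R in compound 2 and S in compound 3): a stereocentre at a saturated ring carbon is drawn R in compound 2 and S in compound 3.

Within the data shown here, no measured pair here shows what such a switch does in this assay. The expectation therefore has to stay close to compound 2 at 3720 nM, with a wide margin on both sides. The expected step is a 1.2-fold higher number from compound 2 to compound 3 (0.08 log units; within the scatter), which would not go beyond the usual scatter and has no firm direction. For compound 3 the estimated value is 4500 nM, with an expected range from 1500 nM to 15000 nM.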

Compound 3, concentration for 50% growth inhibition: 8320 nM
Estimate against measurement, compound 3: 1.8-fold (0.27 log units) below; the range from low to high includes it.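

In this assay, switching this saturated ring carbon from R to S gives a 2.2-fold higher number from compound 2 to compound 3 (0.35 log units; beyond the scatter), so compound 2 is the stronger growth inhibitor of this pair, though the step is modest. Within the data shown here, until now there was only a single number, with nothing to show whether this position mattered; this pair shows that the spatial arrangement at this carbon can move the result beyond the usual scatter, and in which direction. The step can be assigned to this one stereocentre rather than to any added or removed group because of a simple structural fact: the fact that compounds 2 and 3 differ only in the configuration as drawn.

How this happens remains open, since one pair gives the size and direction of the step but no mechanism, and compound 1 offers no number for comparison. It is also unknown whether compound 2 would keep its edge over compound 3 if a free hydroxyl group replaced the silyl ether in both, so this result should be read as applying to this pair alone.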